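The source may hold more compounds than are shown below. What is called first, only, known or untested is meant among the compounds shown, and "the series" means these compounds.

Compound 3 `CC(C)n1ncc2c(C(=O)NCc3cn(-c4cccc(Br)c4)nn3)cccc21` gives 33700 nM in a functional assay on PC-3 cells (Homo sapiens) for inhibition, read by MTT assay, with a stated time of 72 h (on this read-out higher numbers stand for weaker inhibition and lower numbers for stronger inhibition), and so stands highest of the two numbers shown; the nearest number belongs to compound 1 `CC(C)n1ncc2c(C(=O)NCc3ccccc3)cccc21`, which gives 15200 nM in this assay, a gap beyond the usual scatter. Compound 2 `CC(C)n1ncc2c(C(=O)NCc3cn(-c4ccc(I)cc4)nn3)cccc21` is recorded in this assay only as a limit, > 40000 nM. Going by the values given here, the single measured step that touches the aryl group on the ring nitrogen, an at least 1.1-fold lower number from compound 2 to compound 3 (0.07 log units; that floor lies within the scatter), is bounded by the limit of > 40000 nM in this assay, at which 1 of the 3 values shown sits, and therefore tells only that the two compounds sit close together on this read-out.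

Compound 4 `Cc1ccccc1-n1cc(CNC(=O)c2cccc3c2cnn3C(C)C)nn1` differs from compound 3 in one place: 2-methylphenyl in place of 3-bromophenyl on an aromatic nitrogen. Among the compounds with values here, the only comparable step, that from compound 2 to compound 3, was too small to separate from the scatter, so no step beyond the scatter in either direction is expected here. Compound 4 is therefore expected to give about 30000 nM in this assay, with a range from 12000 nM to 45000 nM. That estimate amounts to a step of a 1.1-fold lower number from compound 3 to compound 4 (0.05 log units; within the scatter), within the scatter.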

Compound 4, half-maximal inhibitory concentration: 19200 nM
For compound 4 the middle estimate is 1.6-fold (0.19 log units) above the measured one; low and high end bracket the measured number.
By their numbers in this assay, from the lowest: compounds 1, 4 and 3 (each within the scatter of the next, the first and the last beyond it). At a limit, above all of these: compound 2.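

The exchange of 3-bromophenyl for 2-methylphenyl on the aromatic nitrogen gives a 1.8-fold lower number from compound 3 to compound 4 (0.24 log units; within the scatter), so in this assay these two aryl groups cannot be told apart. Going by these compounds alone, the change from 4-iodophenyl to 2-methylphenyl gives an at least 2.0-fold lower number from compound 2 to compound 4 (0.31 log units; beyond the scatter), the first step at this position to clear the scatter, and it shows that the choice of aryl group can shift the read-out here. Its size remains only a floor because compound 2 is recorded as a limit: the limit of > 40000 nM in this assay, at which 1 of the 4 values shown sits.

The compounds shown do not separate the kind of substituent on the phenyl ring from its place, since 2-methylphenyl and 4-iodophenyl differ in both. From the compounds shown here alone, it also remains open how this read-out would respond to an amine or a carboxylic acid on that ring, or to a longer alkyl chain in place of the aryl group.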